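The source may hold more compounds than are shown below. What is called first, only, known or untested is meant among the compounds shown, and "the series" means these compounds.

Measured in a functional assay on L1210 cells (Mus musculus) for antiproliferative activity, read by cell counting, with a stated time of 2 days; on this read-out lower numbers stand for stronger inhibition and higher numbers for weaker inhibition:
- compound 1 (`COc1cc(C(=O)c2sc(N(C)C)nc2N)cc(OC)c1OC`) gives 11000 nM
- compound 2 (`COc1cc(C(=O)c2sc(N3CCCCC3)nc2N)cc(OC)c1OC`) gives 43000 nM
- compound 3 (`COc1ccccc1C(=O)c1sc(N2CCCC2)nc1N`) gives > 200000 nM (a limit)

Compound 3 has no exact number and sits at the limit of > 200000 nM in this assay, at which 1 of the 3 values shown sits, in the series. Compound 4 (`Nc1nc(N2CCCC2)sc1C(=O)c1ccccc1`) is the next to be tested. It differs from compound 3 by one change (hydrogen in place of methoxy on an aromatic carbon): hydrogen in place of methoxy on an aromatic carbon, ortho to a large group.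

Among the compounds with values here, only one measured step is available, a 3.9-fold higher number from compound 1 to compound 2 (0.59 log units; beyond the scatter), and it is a change at a different place, so it says little about this one. Within the data shown here, no measured step touches the methoxy group, so the size of this change can only be guessed. Compound 3 offers no number to start from, so a clear gain is not expected. The expected change is a number no higher from compound 3 to compound 4 (the limit leaves the size open), which means no clear shift in either direction. For compound 4 the estimate is 200000 nM, with an expected range from 80000 nM to 400000 nM and a good chance that only a limit is reported again.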

Compound 4, half-maximal inhibitory concentration: > 200000 nM
Compound 4 gave a limit, no number (the forecaster's own chance of this, stated with the estimate: 70%); the middle value lies on the limit itself.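

Compound 3 and compound 4 both end at a limit rather than a number, so no step between them can be read: the limit of > 200000 nM in this assay, at which 2 of the 4 values shown sit.

The compounds shown leave open whether swapping methoxy for hydrogen at this place changes the activity at all.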